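Configuration scan at the limit of the assay

The source may report more compounds than this note shows. Statements on the series, on what has been measured and on what is new or still open speak of the compounds shown alone.

- compound 1 `Nc1ncnc2c1ncn2[C@H]1CC[C@@H](O)C1`: > 100000 nM
- compound 2 `Nc1ncnc2c1ncn2[C@@H]1CC[C@H](O)C1`: > 100000 nM

In a functional assay for inhibition, with Homo sapiens as the target (on this read-out lower numbers stand for stronger inhibition and higher numbers for weaker inhibition), compound 2 gives > 100000 nM, which is a limit and not a number. Compound 1 gives > 100000 nM, also a limit. Compound 3 `Nc1ncnc2c1ncn2[C@@H]1CC[C@@H](O)C1` departs from compound 2 in one respect: the two compounds have the same atoms and bonds and differ only in configuration as drawn: 1 of 2 stereo elements differ; a stereocentre at a saturated ring carbon is drawn S in compound 2 and R in compound 3.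

Going by the values given here, the only measured step bearing on this is a step that the two limits leave unreadable from compound 1 to compound 2, which inverts both stereocentres and gives no size to carry over. Both values sit at one ceiling: the limit of > 100000 nM in this assay, at which 2 of the 2 values shown sit. No readable change is expected, in either direction. The expected a number no higher from compound 2 to compound 3 (the limit leaves the size open) is correspondingly small. Compound 3 is expected at 100000 nM, with an estimated range of 40000 nM to 250000 nM.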

Compound 3, half-maximal inhibitory concentration: 76000 nM
The estimate for compound 3 lay 1.3-fold (0.12 log units) above the measured number; low and high end bracket the measured number.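

In this assay, compound 3 gives 76000 nM, which is a number. The mirror-image pair of compound 1 and compound 2 gave only limits. Changing one stereocentre at a saturated ring carbon gives an at least 1.3-fold lower number from compound 2 to compound 3 (0.11 log units; that floor lies within the scatter), and changing the other gives an at least 1.3-fold lower number from compound 1 to compound 3 (0.11 log units; that floor lies within the scatter). Both floors lie within the scatter, so neither single change is shown to matter, and any real size remains unknown.

As far as these compounds go, whether an amine or a carboxylic acid in place of the hydroxyl would give a number in this range stays open.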